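From isopropoxy to cyanomethoxy: compound 3 to compound 4

The source may hold more compounds than are shown below. What is called first, only, known or untested is meant among the compounds shown, and "the series" means these compounds.

Of the compounds shown here, three have been tested in a functional assay on MDBK cells (Bos taurus) for cytotoxicity; on this read-out higher numbers stand for lower toxicity in this test and lower numbers for higher toxicity in this test: compound 1 `CO/N=C(\C#N)C(=O)NCC1=NOC(C)(C)C1`, compound 2 `CO/N=C(/C#N)C(=O)NCC1=NOC(C(C)(C)C)C1` and compound 3 `CC(C)O/N=C(\C#N)C(=O)NCC1=NOC(C(C)(C)C)C1`. Compound 1 gives > 100 ug/mL, which is a limit of the assay. Compound 2 gives > 100 ug/mL, which is also a limit. Compound 3 gives > 100 ug/mL, again a limit and not a number. Within the data shown here, compound 3 therefore stands with the other two, and the series so far comes down to the limit of > 100 ug/mL in this assay, at which 3 of the 3 values shown sit.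

Compound 4 `CC(C)(C)C1CC(CNC(=O)/C(C#N)=N/OCC#N)=NO1` differs from compound 3 in one place: cyanomethyl in place of isopropyl on an oxygen. Cyanomethyl takes the place of isopropyl on an oxygen, so isopropoxy becomes cyanomethoxy. Among the measured compounds shown here, none of the tested compounds carries cyanomethyl, and no measured step offers a direct guide to this change.

Given that compound 3 reports > 100 ug/mL, no step beyond the usual scatter is expected in this assay, although any shift that did appear would be expected toward higher toxicity. The expected size of the change is a number no higher from compound 3 to compound 4 (the limit leaves the size open). For compound 4 the estimated value is 100 ug/mL, with an expected range from 40 ug/mL to 200 ug/mL. The most likely outcome is that the assay again reports only a limit.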

Compound 4, half-maximal cytotoxic concentration: > 100 ug/mL
Compound 4 was reported as a limit; the forecaster's own chance of this, stated with the estimate: 70%; the middle value lies on the limit itself.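

In this assay compound 4 gives > 100 ug/mL as a limit and not a number. Compound 3 also stands at a limit, so no step can be read between compound 3 and compound 4. From the compounds shown here alone, whether cyanomethyl and isopropyl on this oxygen differ at all in this assay remains open, as does the concentration at which any of the four compounds would become toxic.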